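Amino in place of hydrogen on compound 2

The source may report more compounds than this note shows. Statements on the series, on what has been measured and on what is new or still open speak of the compounds shown alone.

Compound 1 `c1coc(-c2ccc3nc(-c4ccco4)cn3c2)c1`: 3000 nM
Compound 2 `c1ccc(-c2ccc3nc(-c4ccco4)cn3c2)cc1`: 420 nM
Compound 3 `Nc1cc(-c2ccco2)cn2cc(-c3ccccc3)nc12`: 26000 nM

These values come from an ADME assay on SH-SY5Y cells (Homo sapiens) for cytotoxicity, read by MTT assay, with a stated time of 72 h; a higher number here means that more compound is tolerated, a lower number that less compound is tolerated. Compound 2 stands lowest of the three at 420 nM. Compound 4 `Nc1cc(-c2ccccc2)cn2cc(-c3ccco3)nc12` differs from it by amino in place of hydrogen on an aromatic carbon. Within the data shown here, no measured step covers this change. The only one is a 7.1-fold lower number from compound 1 to compound 2 (0.85 log units; beyond the scatter), with phenyl in place of furan-2-yl, a group exchange that leaves compound 4 carrying the same phenyl as compound 2. An isomer of compound 4 that also carries amino, compound 3, gives 26000 nM. A rise in this assay beyond the scatter is therefore expected, with the phenyl step keeping it short of compound 3. The expected change is a 9.5-fold higher number from compound 2 to compound 4 (0.98 log units; beyond the scatter). For compound 4 the estimate is 4000 nM, with an expected range of 1000 nM to 16000 nM.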

Compound 4, half-maximal cytotoxic concentration: 500 nM
Beside the measured number, compound 4's estimate is 8.0-fold (0.90 log units) above it; measured number below the stated range.
By their numbers in this assay, from the lowest: compounds 2 and 4 (each within the scatter of the next); then compound 1; then compound 3.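

In this assay, amino in place of hydrogen on this aromatic carbon gives a 1.2-fold higher number from compound 2 to compound 4 (0.08 log units; within the scatter). Among these compounds, this is the first single-place view of the change, and on this core, with its phenyl and furan-2-yl groups, the two compounds cannot be told apart. No measured evidence bears on this result. The compounds shown leave open whether a larger substituent on this carbon, such as a dimethylamino group or a carboxylic acid, would also stay within the scatter. They also leave open whether amino behaves alike on other cores.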